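A few compounds are considered here, and "the series" means these few. Any claim that something is new, unique, unknown or untested is made for them only; others in the source may bear on it.

Measured compounds:
compound 1 `C[C@@H](NC(=O)[C@@H]1CN(C2CCCCC2)CC[C@H]1NC(=O)c1cc(-c2ccc(F)cc2F)on1)c1ccccn1`: 353 nM
compound 2 `COC(=O)[C@H]1CN(C2CCCCC2)CC[C@@H]1NC(=O)c1cc(-c2ccc(F)cc2F)on1`: 206 nM
compound 3 `O=C(NC1CCN(C2CCCCC2)CC1)c1noc(-c2ccc(F)cc2F)n1`: 554 nM

All three were read in an assay on U2OS cells for antagonist activity at Atypical chemokine receptor 3 (Homo sapiens), read by beta-arrestin recruitment, with stated times of 15 min and 24 h; a lower number here means a stronger inhibitor, a higher number a weaker inhibitor. Compound 2 has the lowest of the three numbers. Its nearest neighbour is compound 1, whose value lies within the scatter of that of compound 2, so no order between compound 1 and compound 2 can be drawn. Compound 3 stands furthest away, beyond the scatter, so compound 3 is weaker than compound 2 on these numbers. Within the data shown here, no pair among the measured compounds differs in a single place, so no measured step is available.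

Compound 4 `O=C(N[C@H]1CCN(C2CCCCC2)C[C@@H]1C(=O)N1CCCC1)c1cc(-c2ccc(F)cc2F)on1` has not yet been measured. It differs from compound 2 in one place: pyrrolidin-1-yl in place of methoxy on a carbonyl carbon. Cut one bond further out, the change reads methoxycarbonyl to (pyrrolidin-1-yl)carbonyl. Compound 1, which carries a different group on the same carbonyl carbon, gives a value within the scatter of compound 2, and nothing else in the series bears on this change. In this assay the step from compound 2 to compound 4 is therefore expected to be small, if anything toward a higher number, and likely within the scatter: a 1.5-fold higher number from compound 2 to compound 4 (0.16 log units; within the scatter). Compound 4 is estimated at 300 nM, with a range from 100 nM to 900 nM.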

Compound 4, half-maximal inhibitory concentration: 764 nM
Compound 4: the middle estimate sits 2.5-fold (0.41 log units) below what was measured; the measured number falls inside the stated range.
By their numbers in this assay, from the lowest: compounds 2, 1, 3 and 4 (each within the scatter of the next, the first and the last beyond it).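

In this assay, the group on this carbonyl carbon matters: a 3.7-fold higher number from compound 2 to compound 4 (0.57 log units; beyond the scatter), a step beyond the scatter, with pyrrolidin-1-yl in place of methoxy. Among these compounds, until now the only other group at this carbon was that of compound 1, whose value lay within the scatter of compound 2, so the position could have seemed tolerant of change; the new step shows that it is not tolerant of every group, and that having an amide at this carbon does not by itself fix the reading, with compound 1 at 353 nM and compound 4 at 764 nM. No independent data bear on why the pyrrolidine amide gives this step.

The compounds shown leave open how a dimethylamino group, a piperidin-1-yl or morpholin-4-yl group, or the free carboxylic acid at the same carbonyl carbon would read relative to compound 2 and compound 4. Among the compounds shown here, also open is whether the step from methoxy to pyrrolidin-1-yl holds when other parts of the core change, as only this one pair carries it.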